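The source may report more compounds than this note shows. Statements on the series, on what has been measured and on what is new or still open speak of the compounds shown alone.

In a functional assay on MIA PaCa-2 cells (Homo sapiens) for inhibition, read by MTT assay, with a stated time of 7 days (on this read-out lower numbers stand for stronger inhibition and higher numbers for weaker inhibition), three compounds have been measured so far. Compound 1 `CCN(CC)S(=O)(=O)c1ccc(S(=O)(=O)N2CCC[C@@H](C(=O)NC3CN(C(=O)C4CC4)C3)C2)cc1` gives 2800 nM. Compound 2 `CCOC(=O)C1CCCCN1S(=O)(=O)c1ccc(S(=O)(=O)N(CC)CC)cc1` gives 24600 nM. Compound 3 `CCOC(=O)[C@@H]1CCCN(S(=O)(=O)c2ccc(S(=O)(=O)N3CCCCC3)cc2)C1` gives 2900 nM. Among these three numbers compound 3 holds the second highest: its number and that of compound 1 lie within the scatter of each other, so nothing separates them, while compound 2 sits at a higher number that lies beyond the scatter, meaning weaker inhibition.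

Compound 4 `CCOC(=O)[C@@H]1CCCN(S(=O)(=O)c2ccc(S(=O)(=O)N3CCNCC3)cc2)C1` differs from compound 3 in a single place: piperazin-1-yl in place of piperidin-1-yl on a sulfonyl sulfur. No measured pair among these compounds differs by this same change, so the size of the step cannot be read from the data. The change is small in size and leaves the rest of the molecule untouched, so the step from compound 3 to compound 4 in this assay is expected to be modest, with no clear direction. Compound 4 is therefore expected to give about 4000 nM, most likely between 1200 nM and 13000 nM. This expectation amounts to a step of a 1.4-fold higher number from compound 3 to compound 4 (0.14 log units; within the scatter).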

Compound 4, half-maximal inhibitory concentration: > 30000 nM
Compound 4 gave a limit, no number; the forecaster's own chance of this, stated with the estimate: 5%; middle value at least 7.5-fold (0.87 log units) away from the limit.
By their numbers in this assay, from the lowest: compounds 1 and 3 (each within the scatter of the next); then compound 2. At a limit, above all of these: compound 4.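

In this assay, compound 4 reaches a limit of the assay, > 30000 nM, and not a number: the limit of > 30000 nM in this assay, at which 1 of the 4 values shown sits. Going by these compounds alone, this gives the first comparison here that changes one place only, as compounds 1, 2 and 3 differ from each other in more than one place, and it shows that the group on the sulfonyl sulfur matters: there is an at least 10-fold higher number from compound 3 to compound 4 (1.01 log units; beyond the scatter). The two rings have the same size, yet piperazin-1-yl, with 2 hetero atoms, 1 hydrogen-bond donor and 1 hydrogen-bond acceptor, gives up the activity that piperidin-1-yl retains.

Whether the ring's second nitrogen or its hydrogen accounts for the loss stays open, and a morpholine ring or a piperazine with a methyl group on that nitrogen would help separate the two. This single step also cannot say whether the same change would act alike on the other compounds.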